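Carboxyphenyl Variations in a Glutamate Receptor Modulator Series

A few compounds are considered here, and "the series" means these few. Any claim that something is new, unique, unknown or untested is made for them only; others in the source may bear on it.

Compound 1 `Cc1c(OCCCCOc2ccc(C(=O)O)cc2F)ccc(C(=O)CC2CCCC2)c1O` gives 83.8% in an assay on HEK293 cells for positive allosteric modulation of metabotropic glutamate receptor 2 (Rattus norvegicus), read by thallium flux, with a stated time of 2.5 min; a higher number here means a larger maximal response, a lower number a smaller maximal response.
Compound 2 `Cc1c(OCCCCOc2cccc(C(=O)O)c2)ccc(C(=O)CC2CCCC2)c1O` gives 80.6% in this assay.

For the measured compounds named here, compound 2 holds one of only two numbers in this assay, and its sole neighbour is compound 1: a number 3.2 percentage points lower from compound 1 to compound 2 (within the scatter), so the two compounds cannot be told apart on these data. Compound 3 `Cc1cc(OCCCCOc2ccc(C(=O)CC3CCCC3)c(O)c2C)ccc1C(=O)O` has not yet been measured. It differs from compound 2 in one place: 4-carboxy-3-methylphenyl in place of 3-carboxyphenyl on an oxygen on a saturated carbon.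

Going by the values given here, the only measured step that bears on this change is the one from compound 1 to compound 2, which also exchanged one carboxyphenyl variant for another on the same oxygen, and that step was a number 3.2 percentage points lower from compound 1 to compound 2 (within the scatter), within the scatter. With no other comparison available, the expectation for compound 3 rests on that single step, and a further exchange of the carboxyphenyl group is expected to move the maximal response by no more than the scatter in either direction, so the step of a number 0.4 percentage points higher from compound 2 to compound 3 (within the scatter) is expected. Compound 3 is therefore estimated at 81%, with a likely range from 70% to 92%.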

Compound 3, largest response reached (reported as percent of maximum), in percent of the reference or control that the assay uses: 83.6%
The estimate for compound 3 lay 2.6 percentage points below the measured number; low and high end bracket the measured number.
By their numbers in this assay, from the lowest: compounds 2, 3 and 1 (each within the scatter of the next).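

In this assay, placing the 4-carboxy-3-methylphenyl group on the oxygen on a saturated carbon gives a number 3 percentage points higher from compound 2 to compound 3 (within the scatter) against the 3-carboxyphenyl group and a number 0.2 percentage points lower from compound 1 to compound 3 (within the scatter) against the 4-carboxy-2-fluorophenyl group. Where the earlier compounds offered only one comparison at this place, there are now three carboxyphenyl variants on the same core, and the maximal response does not separate any of them, so a methyl-bearing ring, a fluorine-bearing ring and a ring with neither cannot be told apart on these numbers. Nothing at hand offers an explanation for this result.

Going by these compounds, all three compounds keep a carboxylic acid on the phenyl ring and the same saturated chain, so what a tetrazole or a primary amide in place of the acid, or a longer chain, would do to the maximal response remains open. These numbers also speak only to the largest response reached, which leaves open whether compounds that match on this read-out also match in the concentration needed to reach it.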